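Working notes on the side chain carried by the shared core

The source may hold more compounds than are shown below. What is called first, only, known or untested is meant among the compounds shown, and "the series" means these compounds.

Measured so far:
compound 1, `Cc1nn(-c2ncnc3nc[nH]c23)c2c1C(OCc1ccc(C(C)C)cc1)CC(=O)N2` — 5 nM
compound 2, `Cc1nn(-c2ncnc3nc[nH]c23)c2c1C(c1ccc(OC(C)C)cc1)CC(=O)N2` — 18 nM

Both compounds were tested in a functional assay on HEK293 cells for agonist activity at G-protein coupled receptor 39 (Homo sapiens), read by scintillation proximity assay and inositol phosphate accumulation, with a stated time of 75 min, in the presence of a further agent that is not named here; on this read-out higher numbers stand for an effect only at larger amounts of compound and lower numbers for an effect already at smaller amounts. Compound 1 gives the lower of the two numbers in this assay, and compound 2 sits beyond the scatter from it, so compound 1 is the more potent of the pair as far as these two values go. Within the data shown here, nothing more can be read from the pair, since no single-point step between them is given.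

Compound 3, `COc1ccc(CCOC2CC(=O)Nc3c2c(C)nn3-c2ncnc3nc[nH]c23)cc1`, is not yet measured in this assay. It differs from compound 1 in one place: 4-methoxybenzyl in place of 4-isopropylphenyl on a saturated chain carbon bound to an oxygen on a saturated carbon. Seen one bond further out, 4-isopropylbenzyl gives way to 2-(4-methoxyphenyl)ethyl.

There is no measured step of this kind in the series, so the expectation rests on compound 1 alone and on the size of the change. A loss beyond the scatter is expected; the step of a 6.0-fold higher number from compound 1 to compound 3 (0.78 log units; beyond the scatter) is the estimated size. For compound 3 the estimate in this assay is 30 nM, within a range from 8 nM to 120 nM.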

Compound 3, half-maximal effective concentration: 2 nM
Estimate against measurement, compound 3: 15-fold (1.18 log units) above; measured number below the stated range.
By their numbers in this assay, from the lowest: compound 3; then compound 1; then compound 2.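

In this assay, among these compounds, 4-methoxybenzyl in place of 4-isopropylphenyl on a saturated chain carbon bound to an oxygen on a saturated carbon gives a 2.5-fold lower number from compound 1 to compound 3 (0.40 log units; beyond the scatter), a modest gain in potency and the only single-place step so far. It shows that this side chain can be changed in both its ring substituent and its length without losing potency: read one bond further out, 2-(4-methoxyphenyl)ethyl replaces 4-isopropylbenzyl, and the entering group holds one hydrogen-bond acceptor where the leaving group holds none. Nothing measured here bears on what lies behind this step.

The step changes two features at once, so the compounds shown leave open how much of it belongs to the methoxy group and how much to the 2-(4-methoxyphenyl)ethyl chain, a question that 2-(4-isopropylphenyl)ethyl on the same oxygen would help to separate. Also open, going by these compounds, is how far the chain and ring can be varied, for example with a 3-(4-methoxyphenyl)propyl chain, or with an amine or a carboxylic acid in place of the methoxy group.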